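Swapping Fluoro for Cyano on the Benzyl Group

This account rests on a few compounds, and the source may have more. Where it says the series, first, only, none or still open, it means among the compounds named here.

Two close relatives set the scene: compound 1 `Cc1cccc(CN2CCC(c3noc(CN(C)c4ncc(C(=O)NO)cn4)n3)CC2)c1` and compound 2 `CN(Cc1nc(C2CCN(Cc3ccc(F)cc3)CC2)no1)c1ncc(C(=O)NO)cn1` differ in one place only. In a functional assay on Raji cells (Homo sapiens) for antiproliferative activity, read by MTT assay, with a stated time of 72 h (on this read-out higher numbers stand for weaker inhibition and lower numbers for stronger inhibition), compound 1 gives 47.3 nM and compound 2 gives 22 nM as the lower of the two numbers, which makes compound 2 the stronger inhibitor so far.

The next molecule is compound 3 `CN(Cc1nc(C2CCN(Cc3ccc(C#N)cc3)CC2)no1)c1ncc(C(=O)NO)cn1`, which keeps everything except one small group. The difference is cyano in place of fluoro on an aromatic carbon so that 4-fluorobenzyl becomes 4-cyanobenzyl.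

Among the compounds with values here, the one measured step in this part of the molecule is a 2.2-fold lower number from compound 1 to compound 2 (0.33 log units; beyond the scatter) and it is modest, coming with the swap of 3-methylphenyl for 4-fluorophenyl. Within the data shown here, that swap is a different exchange, and no measured compound carries a cyano group, so the direction of the new step remains uncertain. The step expected in this assay is a 1.3-fold higher number from compound 2 to compound 3 (0.10 log units; within the scatter) and it is not expected to go beyond the scatter. For compound 3 the estimated value is 28 nM with an expected range from 10 nM to 75 nM once it is measured.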

Compound 3, half-maximal inhibitory concentration: 117 nM
For compound 3 the middle estimate is 4.2-fold (0.62 log units) below the measured one; the measured number lies above the stated range.
By their numbers in this assay, from the lowest: compound 2; then compound 1; then compound 3.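

In this assay, within the data shown here, the earlier pair showed only that the benzyl group can be changed with a modest gain, whereas this result shows that the same part of the molecule can also lose activity. Cyano on the aromatic carbon that held fluoro, a change of only one heavy atom to two, gives a 5.3-fold higher number from compound 2 to compound 3 (0.73 log units; beyond the scatter) and so reverses the direction of the earlier step. The new group also falls behind the 3-methylphenyl of the first compound, with a 2.5-fold higher number from compound 1 to compound 3 (0.39 log units; beyond the scatter) as the step, which makes compound 3 the weakest of the three, since its steps to both others are beyond the scatter.

No measurement available here explains why cyano behaves so differently from fluoro.

From the compounds shown here alone, with only three benzyl variants, it remains open whether this loss belongs to cyano alone or would also appear with other groups in the same place, such as chloro, methoxy or an amine. A plain benzyl group carrying no substituent would give a baseline for judging whether fluoro helps, cyano harms, or both.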